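Branched nitrogen substituents in the 5-alpha-reductase series

A few compounds are considered here, and "the series" means these few. Any claim that something is new, unique, unknown or untested is made for them only; others in the source may bear on it.

Compound 3 `C/C(=C\C(=O)Nc1ccccc1OCCCC(=O)O)c1ccc2c(ccn2Cc2ccc(F)cc2)c1` stands second highest of the three numbers in an assay on Prostate gland for inhibition of steroid 5-alpha-reductase (Rattus norvegicus); a lower number here means a stronger inhibitor, a higher number a weaker inhibitor: compound 3 gives 97 nM, compound 1 `C/C(=C\C(=O)Nc1ccccc1OCCCC(=O)O)c1ccc2c(ccn2CC(C)C)c1` gives 160 nM, and compound 2 `CCCCC(C)n1ccc2cc(/C(C)=C/C(=O)Nc3ccccc3OCCCC(=O)O)ccc21` gives 6 nM. Compound 4 `CCCC(c1ccccc1)n1ccc2cc(/C(C)=C/C(=O)Nc3ccccc3OCCCC(=O)O)ccc21` differs from compound 3 in one place: 1-phenylbutyl in place of 4-fluorobenzyl on an aromatic nitrogen. Among the compounds with values here, two measured steps bear on this change. The step of a 27-fold lower number from compound 1 to compound 2 (1.43 log units; beyond the scatter) shows that a branched chain at the nitrogen carries a large gain, and the step of a 16-fold higher number from compound 2 to compound 3 (1.21 log units; beyond the scatter) shows that replacing that branched chain with the 4-fluorobenzyl group gives most of that gain back. The entering 1-phenylbutyl group is branched at the carbon attached to the nitrogen, as the 1-methylpentyl group of compound 2 is, and retains an aromatic ring as compound 3 does. A step downward in this assay, beyond the scatter but not necessarily reaching compound 2, is therefore expected for compound 4, about a 6.5-fold lower number from compound 3 to compound 4 (0.81 log units; beyond the scatter). Compound 4 is estimated at 15 nM, within a range of 4 nM to 60 nM.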

Compound 4, half-maximal inhibitory concentration: 9.1 nM
The estimate for compound 4 lay 1.6-fold (0.22 log units) above the measured number; the measured number falls inside the stated range.
By their numbers in this assay, from the lowest: compounds 2 and 4 (each within the scatter of the next); then compounds 3 and 1 (each within the scatter of the next).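

In this assay a branch at the carbon on the aromatic nitrogen now proves compatible with a phenyl ring in the same substituent, with an 11-fold lower number from compound 3 to compound 4 (1.03 log units; beyond the scatter) against the unbranched 4-fluorobenzyl group. The gain also holds against isobutyl, with an 18-fold lower number from compound 1 to compound 4 (1.25 log units; beyond the scatter) on that comparison. Swapping the chain end of the branched group for a phenyl ring leaves the number within the scatter, with a 1.5-fold higher number from compound 2 to compound 4 (0.18 log units; within the scatter) as the step, so 1-phenylbutyl and 1-methylpentyl serve equally here.

The step from compound 3 changes the branch, the chain and the fluorine together, and a plain benzyl or a 1-phenylethyl group on this nitrogen would separate those parts. No measurement at hand gives a reason for the level of the branched groups.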